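The source may hold more compounds than are shown below. What is called first, only, known or untested is meant among the compounds shown, and "the series" means these compounds.

In a functional assay on QGY-7703 cells (Homo sapiens) for cytotoxicity, read by MTT assay, with a stated time of 24 h (a lower number here means a stronger inhibitor, a higher number a weaker inhibitor), compound 1 (`O=C1/C(=C/c2cccnc2)CN(S(=O)(=O)c2ccccc2)C/C1=C\c1ccccc1C(F)(F)F`) gives 6240 nM while compound 2 (`O=C1/C(=C/c2cccnc2)CN(S(=O)(=O)c2ccc(C(F)(F)F)cc2)C/C1=C\c1ccccc1C(F)(F)F`) gives 1500 nM and compound 3 (`O=C1/C(=C/c2cccnc2)CN(S(=O)(=O)c2ccc(Br)cc2)C/C1=C\c1ccccc1C(F)(F)F`) gives 5510 nM on the same shared core. Bromo in place of hydrogen barely moves the number (a 1.1-fold lower number from compound 1 to compound 3 (0.05 log units; within the scatter)), so compound 3 stands level with compound 1. Trifluoromethyl in place of hydrogen lowers the number (a 4.2-fold lower number from compound 1 to compound 2 (0.62 log units; beyond the scatter)) and bromo in place of trifluoromethyl raises it again (a 3.7-fold higher number from compound 2 to compound 3 (0.57 log units; beyond the scatter)). Compound 4 (`N#Cc1ccc(S(=O)(=O)N2C/C(=C\c3cccnc3)C(=O)/C(=C/c3ccccc3C(F)(F)F)C2)cc1`) has cyano in place of bromo on an aromatic carbon. Among the compounds with values here, no measured compound carries cyano, and compound 2 at 1500 nM shows the only clear drop, so a small step to a lower number is expected (a 1.8-fold lower number from compound 3 to compound 4 (0.26 log units; within the scatter)), not clearly beyond the scatter. For compound 4 the estimated value is 3000 nM (expected range 1300 nM to 6500 nM).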

Compound 4, half-maximal inhibitory concentration: 6150 nM
Beside the measured number, compound 4's estimate is 2.1-fold (0.31 log units) below it; the range from low to high includes it.
By their numbers in this assay, from the lowest: compound 2; then compounds 3, 4 and 1 (each within the scatter of the next).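

In this assay, 4-cyanophenyl stands level with 4-bromophenyl (a 1.1-fold higher number from compound 3 to compound 4 (0.05 log units; within the scatter)) and with hydrogen at this place (a 1.0-fold lower number from compound 1 to compound 4 (0.01 log units; within the scatter)), while trifluoromethyl stays apart (a 4.1-fold higher number from compound 2 to compound 4 (0.61 log units; beyond the scatter)). The one clear drop in the number therefore remains with compound 2, and now two other groups at this place, bromo and cyano, fail to reproduce it. Nothing available here accounts for that difference. Whether any other group can match trifluoromethyl stays open, since the compounds shown include no amine, methoxy group or carboxylic acid on this aromatic carbon.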